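A few compounds are considered here, and "the series" means these few. Any claim that something is new, unique, unknown or untested is made for them only; others in the source may bear on it.

Compounds 1, 2 and 3 share one core and differ only in the halogen on the thioether aryl. Compound 1 `CC(O)(CSc1ccc(Cl)cc1)c1nc(-c2ccccc2)no1` gives in a functional assay on DU-145 cells (Homo sapiens) for cytotoxicity, read by MTT assay (on this read-out lower numbers stand for stronger inhibition and higher numbers for weaker inhibition), 70700 nM. Compound 2 `CC(O)(CSc1ccc(F)cc1)c1nc(-c2ccccc2)no1` reaches in this assay only > 100000 nM, which is a limit of the assay and not a number. Compound 3 `CC(O)(CSc1ccc(Br)cc1)c1nc(-c2ccccc2)no1` likewise reaches only > 100000 nM, again a limit. The measured steps are an at least 1.4-fold higher number from compound 1 to compound 2 (0.15 log units; that floor lies within the scatter), an at least 1.4-fold higher number from compound 1 to compound 3 (0.15 log units; that floor lies within the scatter) and a step that the two limits leave unreadable from compound 2 to compound 3, set against (the limit of > 100000 nM in this assay, at which 2 of the 3 values shown sit). Compound 2 thus stands at the limit, among the weaker values shown. Compound 4 `CC(O)(CSc1ccc(F)cc1)c1nc(-c2ccc(F)c(Cl)c2)no1` differs from compound 2 by 3-chloro-4-fluorophenyl in place of phenyl on an aromatic carbon. Among the measured compounds shown here, none of the measured steps concerns this position, and none was readable beyond the scatter. Compound 4 is therefore expected to remain near the limit, estimated at 100000 nM with a range from 30000 nM to 300000 nM. The step this estimate means, a number no higher from compound 2 to compound 4 (the limit leaves the size open), is expected to be none beyond the scatter.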

Compound 4, half-maximal inhibitory concentration: 2900 nM
Beside the measured number, compound 4's estimate is 34-fold (1.54 log units) above it, outside the stated range (below it).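

Among the compounds shown here, the halogen changes on the thioether aryl gave no step readable beyond the scatter, but this position does: in this assay, 3-chloro-4-fluorophenyl in place of phenyl gives an at least 34-fold lower number from compound 2 to compound 4 (1.53 log units; beyond the scatter). The read-out therefore responds strongly to the group on this aromatic carbon, at least in the pair shown. Only a floor can be given for the size of the step, because compound 2 sits at a limit: the limit of > 100000 nM in this assay, at which 2 of the 4 values shown sit.

As far as these compounds go, whether the chloro or the fluoro of the new group carries the step stays open, as does whether it would also appear with the thioether aryl of compound 1 or compound 3. From the compounds shown here alone, how an amine or a carboxylic acid on this phenyl would read also stays open.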